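Isobutyl to butyl on a shared core

A few compounds are considered here, and "the series" means these few. Any claim that something is new, unique, unknown or untested is made for them only; others in the source may bear on it.

Measured in a functional assay on FaDu cells (Homo sapiens) for cytotoxicity, read by MTT assay, with a stated time of 72 h; on this read-out higher numbers stand for lower toxicity in this test and lower numbers for higher toxicity in this test:
Compound 1 `COC(=O)CCn1cc(C(=O)C(=O)Nc2ccc(OC)nc2)c2ccccc21`: 168 nM
Compound 2 `COc1ccc(NC(=O)C(=O)c2cn(CC(C)C)c3ccccc23)cn1`: 317 nM

Compound 2 has a single measured neighbour, and the step between them, a 1.9-fold higher number from compound 1 to compound 2 (0.28 log units; within the scatter), lies within the scatter, so the two values cannot be told apart. Compound 3 `CCCCn1cc(C(=O)C(=O)Nc2ccc(OC)nc2)c2ccccc21` carries propyl in place of isopropyl on a saturated chain carbon bound to an aromatic nitrogen. Among the compounds with values here, the step to compound 2 changed the same place and is the only evidence, so no shift beyond the scatter is expected in this assay. The expected step is a 1.3-fold lower number from compound 2 to compound 3 (0.12 log units; within the scatter). Compound 3 is estimated at 240 nM, with an expected range of 100 nM to 580 nM.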

Compound 3, concentration lethal to 50% of the cells: 18 nM
The estimate for compound 3 lay 13-fold (1.12 log units) above the measured number; the whole stated range lies above it.
By their numbers in this assay, from the lowest: compound 3; then compounds 1 and 2 (each within the scatter of the next).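

In this assay this position, on a saturated chain carbon bound to an aromatic nitrogen, responds strongly to how the chain is joined: the isobutyl to butyl change gives an 18-fold lower number from compound 2 to compound 3 (1.25 log units; beyond the scatter) with no atom gained or lost. The butyl chain also separates from the methoxycarbonyl-bearing chain, with a 9.3-fold lower number from compound 1 to compound 3 (0.97 log units; beyond the scatter), although the earlier pair could not be told apart. Nothing available here accounts for this difference. Going by these compounds, whether a longer chain such as pentyl would hold the number of compound 3 remains open. So does the effect of an amine or a carboxylic acid at the end of the butyl chain.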